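Swapping Methyl for Cyclopropyl on a Quickly Removed Compound

The source may report more compounds than this note shows. Statements on the series, on what has been measured and on what is new or still open speak of the compounds shown alone.

In an in vitro ADME assay on microsomes (Rattus norvegicus) for metabolic stability (a higher number here means faster removal of the compound, a lower number slower removal), compound 1 (`O=C(CN1C[C@H](NC(=O)c2ccc(Cl)s2)[C@@H](OCC(F)F)C1)Nc1ccc(-n2ccccc2=O)cc1F`) gives 35 mL.min-1.g-1 and compound 2 (`CC1CN(CC(=O)Nc2ccc(-n3ccccc3=O)cc2F)CC1NC(=O)c1ccc(Cl)s1`) gives 166 mL.min-1.g-1 as its measured number. Compound 2 therefore holds the higher of the two numbers, and its gap to compound 1 lies beyond the usual scatter of repeated measurements. These two compounds differ in more than one place, so their gap cannot be pinned on any single structural feature.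

The next compound is compound 3 (`O=C(CN1CC(NC(=O)c2ccc(Cl)s2)C(C2CC2)C1)Nc1ccc(-n2ccccc2=O)cc1F`), which carries cyclopropyl in place of methyl on a saturated ring carbon and is otherwise the same as compound 2. For the measured compounds named here, no measured pair shows a change of this kind, so the expectation starts from compound 2 at 166 mL.min-1.g-1 and stays cautious. A small upward move in this assay is expected, with the estimated step of a 1.1-fold higher number from compound 2 to compound 3 (0.06 log units; within the scatter) staying within the scatter. Compound 3 is estimated at 190 mL.min-1.g-1 with an expected range of 85 mL.min-1.g-1 to 400 mL.min-1.g-1 for its measurement.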

Compound 3, intrinsic clearance in microsomes: 109 mL.min-1.g-1
Compound 3: the middle estimate sits 1.7-fold (0.24 log units) above what was measured, within the range that was stated.
By their numbers in this assay, from the lowest: compound 1; then compounds 3 and 2 (each within the scatter of the next).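

In this assay, for the compounds shown here, putting cyclopropyl in place of methyl on a saturated ring carbon gives a 1.5-fold lower number from compound 2 to compound 3 (0.18 log units; within the scatter), the first comparison in which only this one place changes. Going from 1 heavy atom to 3 heavy atoms, and adding a three-membered ring of carbon only, therefore leaves compound 2 and compound 3 indistinguishable in this read-out, so this pair gives no sign that the size of this carbon group matters here. Nothing measured here offers a reason for this result.

Going by these compounds, this is a single pair, so it shows only how these two groups compare in this one setting and sets no general rule for the position, and whether the same swap would behave alike on another core also stays unknown. Whether a group of a different kind on this ring carbon, such as an amine, a carboxylic acid or a longer carbon chain like n-butyl, would shift the number beyond the scatter remains an open question.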